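Thiophene for methylfuran on the fused core, notes

The source may hold more compounds than are shown below. What is called first, only, known or untested is meant among the compounds shown, and "the series" means these compounds.

Of the compounds shown here, two have been measured in a functional assay on CHO cells for agonist activity at adenosine receptor A2b (Homo sapiens), read by scintillation counting and cAMP accumulation, with a stated time of 150 min, in the presence of a further agent that is not named here; on this read-out lower numbers stand for stronger inhibition and higher numbers for weaker inhibition. Compound 1 `COc1cccc(CNc2nc(N)c3nc(-c4cccs4)sc3n2)c1` gives 2770 nM. Compound 2 `COc1ccccc1CNc1nc(N)c2nc(-c3ccc(C)o3)sc2n1` gives 389 nM, the lowest of the two numbers; compound 1 stands at the higher number, and the gap between them lies beyond the usual scatter. Within the data shown here, compound 1 and compound 2 differ in more than one place, so their two values show only that the pair is far apart, not which change carries the gap.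

Compound 3 `COc1ccccc1CNc1nc(N)c2nc(-c3cccs3)sc2n1` comes from compound 2 by one change: thiophen-2-yl in place of 5-methylfuran-2-yl on an aromatic carbon. Among the measured compounds shown here, no measured pair tells the size of this step. Compound 3 keeps the methoxybenzyl group of compound 2, and the move from compound 2 to compound 3 is expected to give a modest rise in the number, a 2.3-fold higher number from compound 2 to compound 3 (0.36 log units; beyond the scatter), landing well below compound 1 at 2770 nM. For compound 3 the estimate in this assay is 900 nM, with a range from 300 nM to 3000 nM.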

Compound 3, half-maximal inhibitory concentration: 4570 nM
Compound 3: the middle estimate sits 5.1-fold (0.71 log units) below what was measured; the measured number lies above the stated range.
By their numbers in this assay, from the lowest: compound 2; then compounds 1 and 3 (each within the scatter of the next).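

In this assay, the change at this aromatic carbon now stands alone as a large step, with thiophen-2-yl in place of 5-methylfuran-2-yl and the 2-methoxyphenyl group unchanged (a 12-fold higher number from compound 2 to compound 3 (1.07 log units; beyond the scatter)). With thiophen-2-yl held constant, 2-methoxyphenyl in place of 3-methoxyphenyl gives a step that stays within the scatter (a 1.6-fold higher number from compound 1 to compound 3 (0.22 log units; within the scatter)), so this pair does not separate the two methoxy placements. Nothing available accounts for the size of the step at the five-membered ring.

The compounds shown do not settle whether the step follows the methyl group or the ring exchange, which furan-2-yl and 5-methylthiophen-2-yl at the same carbon would separate. As far as these compounds go, whether the methoxy placement stays equally silent alongside 5-methylfuran-2-yl also remains open.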